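Series notes: second chloro on the benzyl group

The source may report more compounds than this note shows. Statements on the series, on what has been measured and on what is new or still open speak of the compounds shown alone.

Among the compounds with values here, compound 3 `O=C(NOCc1ccccc1Cl)c1cn(-c2ccccc2)nc1-c1ccc(F)cc1` gives 36400 nM in a functional assay on HeLa cells (Homo sapiens) for antiproliferative activity, read by MTT assay, with a stated time of 48 h, in the presence of a further agent that is not named here (on this read-out higher numbers stand for weaker inhibition of growth and lower numbers for stronger inhibition of growth), and stands highest of the three numbers measured so far. Compound 2 `O=C(NOCc1ccc(Cl)cc1Cl)c1cn(-c2ccccc2)nc1-c1ccc(Cl)cc1` gives 5160 nM and compound 1 `Cc1ccc(-c2nn(-c3ccccc3)cc2C(=O)NOCc2ccc(Cl)cc2Cl)cc1` gives 2040 nM. Within the data shown here, the only step between compounds that differ in one place, a 2.5-fold higher number from compound 1 to compound 2 (0.40 log units; beyond the scatter), is a chloro in place of methyl on an aromatic carbon. Compound 4 `O=C(NOCc1ccc(Cl)cc1Cl)c1cn(-c2ccccc2)nc1-c1ccc(F)cc1` differs from compound 3 by chloro in place of hydrogen on an aromatic carbon. Among the measured compounds shown here, no measured step covers this change directly; compounds 1 and 2, which both carry the 2,4-dichlorobenzyl, give lower numbers than compound 3, but each differs from it in two places. A modest lowering is therefore expected, a 4.0-fold lower number from compound 3 to compound 4 (0.61 log units; beyond the scatter). Compound 4 is estimated at 9000 nM, within 2500 nM to 30000 nM.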

Compound 4, concentration for 50% growth inhibition: 7350 nM
Compound 4: middle estimate off by 1.2-fold (0.09 log units), on the high side; the measured number falls inside the stated range.
By their numbers in this assay, from the lowest: compound 1; then compounds 2 and 4 (each within the scatter of the next); then compound 3.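

Chloro in place of hydrogen, para to a large group, now has a direct reading in this assay: 2-chlorobenzyl to 2,4-dichlorobenzyl gives a 5.0-fold lower number from compound 3 to compound 4 (0.69 log units; beyond the scatter), so this chloro counts on its own. With the 2,4-dichlorobenzyl held, fluoro in place of chloro on the other aromatic ring gives a 1.4-fold higher number from compound 2 to compound 4 (0.15 log units; within the scatter), which does not separate the two halogens. Fluoro in place of methyl there gives a 3.6-fold higher number from compound 1 to compound 4 (0.56 log units; beyond the scatter), so methyl keeps its edge over fluoro.

As far as these compounds go, whether a methoxy group or an amine at the chloro's place would serve as well remains open. No evidence bears on why this chloro matters.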